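Moving the ester one carbon away from the urea nitrogen

A few compounds are considered here, and "the series" means these few. Any claim that something is new, unique, unknown or untested is made for them only; others in the source may bear on it.

Compound 1 `Cc1cn([C@@H]2O[C@H](CO[Si](C)(C)C(C)(C)C)[C@@]3(OS(=O)(=O)C=C3NC(=O)NC(=O)c3ccccc3)[C@H]2O[Si](C)(C)C(C)(C)C)c(=O)n(C)c1=O` gives in an ADME assay on HEL cells (Homo sapiens) for cytotoxicity, with a stated time of 3 days (a lower number here means that less compound is tolerated, a higher number that more compound is tolerated), a result that is a limit of the assay rather than a number, > 200000 nM. Compound 2 `Cc1cn([C@@H]2O[C@H](CO[Si](C)(C)C(C)(C)C)[C@@]3(OS(=O)(=O)C=C3NC(=O)NCc3ccccc3)[C@H]2O[Si](C)(C)C(C)(C)C)c(=O)n(C)c1=O` gives in this assay 4100 nM. Compound 3 `CCOC(=O)NC(=O)NC1=CS(=O)(=O)O[C@@]12[C@@H](CO[Si](C)(C)C(C)(C)C)O[C@@H](n1cc(C)c(=O)n(C)c1=O)[C@@H]2O[Si](C)(C)C(C)(C)C` gives in this assay 14000 nM.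

Among the two numbers shown, compound 3 stands highest; the nearest is compound 2, and the step runs a 3.4-fold higher number from compound 2 to compound 3 (0.53 log units; beyond the scatter). For compound 1 only the limit is known (the limit of > 200000 nM in this assay, at which 1 of the 3 values shown sits).

Compound 4 `CCOC(=O)CNC(=O)NC1=CS(=O)(=O)O[C@@]12[C@@H](CO[Si](C)(C)C(C)(C)C)O[C@@H](n1cc(C)c(=O)n(C)c1=O)[C@@H]2O[Si](C)(C)C(C)(C)C` differs from compound 3 by (ethoxycarbonyl)methyl in place of ethoxycarbonyl on an amide-type nitrogen. For the measured compounds named here, two measured steps bear on this. Exchanging an acyl group for an alkyl group on the same amide-type nitrogen went an at least 48-fold lower number from compound 1 to compound 2 (1.68 log units; beyond the scatter), a large move to a lower number. Replacing the benzyl of compound 2 by ethoxycarbonyl went a 3.4-fold higher number from compound 2 to compound 3 (0.53 log units; beyond the scatter). The third step, an at least 14-fold lower number from compound 1 to compound 3 (1.15 log units; beyond the scatter), changed the carbonyl substituent and is less directly comparable. Since compound 4 also carries a methylene rather than a carbonyl on that nitrogen, a modest step to a lower number is expected, a 2.3-fold lower number from compound 3 to compound 4 (0.37 log units; beyond the scatter). Compound 4 is therefore estimated at 6000 nM, with a likely range from 2000 nM to 20000 nM.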

Compound 4, half-maximal cytotoxic concentration: 13000 nM
Compound 4: middle estimate off by 2.2-fold (0.34 log units), on the low side; the range from low to high includes it.
By their numbers in this assay, from the lowest: compound 2; then compounds 4 and 3 (each within the scatter of the next). At a limit, above all of these: compound 1.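

The step of a 1.1-fold lower number from compound 3 to compound 4 (0.03 log units; within the scatter) shows that in this assay a methylene added on this amide-type nitrogen leaves the ester-bearing compound within the scatter, so (ethoxycarbonyl)methyl and ethoxycarbonyl cannot be told apart here. With the saturated chain carbon held in place, ethoxycarbonyl in place of phenyl gives the step of a 3.2-fold higher number from compound 2 to compound 4 (0.50 log units; beyond the scatter), so here the end group on the chain, not the carbonyl on the nitrogen, goes with the change. Compound 1 stands at a limit of the assay, so the step of an at least 15-fold lower number from compound 1 to compound 4 (1.18 log units; beyond the scatter) is a bound only: the limit of > 200000 nM in this assay, at which 1 of the 4 values shown sits.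

The compounds shown leave open whether a carboxylic acid in place of the ethyl ester, or a longer chain carrying it, would stay in this range. Also open, as far as these compounds go, is whether phenylacetyl on that nitrogen would reach the limit of compound 1.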